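Bisaryl Piperidines in a Rabbit Aorta Functional Assay

The source may report more compounds than this note shows. Statements on the series, on what has been measured and on what is new or still open speak of the compounds shown alone.

The measured compounds and their values:
Compound 1, `COc1cc(C(C)=O)ccc1OCCCN1CCC(C(c2ccccc2)c2ccc(F)cc2)CC1`, gives 6.31 nM.
Compound 2, `COc1cc(C(C)=O)ccc1OCCCCN1CCC(C(c2ccc(F)cc2)c2ccc(F)cc2)CC1`, gives 2.51 nM.
Compound 3, `NC(=O)c1ccc(OCCCN2CCC(C(c3ccc(F)cc3)c3ccc(F)cc3)CC2)cc1`, gives 31.6 nM.

All three were tested in a functional assay (aorta) with Oryctolagus cuniculus as the target; a lower number here means tighter binding, a higher number weaker binding. Among them compound 3 stands with the highest number; its nearest neighbour is compound 1, and the gap to compound 2 is the widest of the three, both gaps lying beyond the scatter. Compound 3 is therefore the weakest of the measured set.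

The unmeasured compound 4, `CN(CCCN1CCC(C(c2ccc(F)cc2)c2ccc(F)cc2)CC1)c1ccccc1`, is obtained from compound 3 by a single exchange: methyl(phenyl)amino in place of 4-carbamoylphenoxy on a saturated chain carbon, three bonds along the chain from an amine nitrogen in a ring. Going by the values given here, no pair of measured compounds differs in only one place, so this change has no directly measured counterpart here.

The shared core is held constant, and the two more potent compounds carry an aryl ether side chain of a different kind. On that basis compound 4 is expected to move in the direction of a lower number, by a step of about a 2.1-fold lower number from compound 3 to compound 4 (0.32 log units; beyond the scatter), close to the edge of the scatter. The estimate for compound 4 is 15 nM, with a range from 4 nM to 60 nM.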

Compound 4, dissociation constant: 2 nM
Compound 4: middle estimate off by 7.5-fold (0.88 log units), on the high side; measured number outside the range, below it.
By their numbers in this assay, from the lowest: compounds 4 and 2 (each within the scatter of the next); then compound 1; then compound 3.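

In this assay, going by these compounds alone, the exchange of 4-carbamoylphenoxy for methyl(phenyl)amino, on a saturated chain carbon three bonds along the chain from an amine nitrogen in a ring, gives a 16-fold lower number from compound 3 to compound 4 (1.20 log units; beyond the scatter) and is the first comparison here in which only one place differs. It shows that this place accepts a group without the carbamoyl and without any oxygen, and that a hydrogen-bond donor in the group is not needed for compound 4 to reach 2 nM in this assay on this core. Nothing available here bears on why the number falls.

The exchange alters several features at once, so it leaves open whether the gain follows the loss of the carbamoyl or the arrival of the methylated nitrogen; a plain phenoxy or a phenylamino group at this place would separate the two. As far as these compounds go, how a longer chain would read with methyl(phenyl)amino also remains open.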